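One Halogen for Another, from Compound 2 to Compound 3

The source may report more compounds than this note shows. Statements on the series, on what has been measured and on what is new or still open speak of the compounds shown alone.

Of the compounds shown here, two have so far been measured in an assay on U2OS cells for activation of nuclear factor erythroid 2-related factor 2 (Homo sapiens), read by beta-arrestin recruitment, with a stated time of 6 h; a higher number here means that more compound is needed for the effect, a lower number that less compound is needed. Compound 1, `O=S(=O)(/C=C/c1ncccc1F)c1ccccc1F`, gives 176 nM. Compound 2, `O=S(=O)(/C=C/c1cccnc1Cl)c1cccc(F)c1`, gives 328 nM. Within the data shown here, on these two numbers compound 2 stands at the higher end, yet its only neighbour is compound 1, and the gap between them lies within the usual scatter of repeated runs, so the two cannot be told apart on the evidence at hand.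

Compound 3, `O=S(=O)(/C=C/c1cccnc1Cl)c1cccc(Cl)c1`, has not yet been measured. It differs from compound 2 in a single place: chloro in place of fluoro on an aromatic carbon. Among the measured compounds shown here, no pair of measured compounds shows what this particular swap does in this assay, so there is no measured step to lean on. Given how small the change is in what is counted, the expected step is modest, of a size within the scatter and of no settled direction: a 1.1-fold lower number from compound 2 to compound 3 (0.04 log units; within the scatter). Compound 3 is therefore estimated to give about 300 nM, with a likely range from 120 nM to 800 nM.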

Compound 3, half-maximal effective concentration: 213 nM
For compound 3 the middle estimate is 1.4-fold (0.15 log units) above the measured one; low and high end bracket the measured number.
By their numbers in this assay, from the lowest: compounds 1, 3 and 2 (each within the scatter of the next).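

Among these compounds, the readings in this assay now give a first measured step for chloro in place of fluoro on an aromatic carbon, meta to a large group: a 1.5-fold lower number from compound 2 to compound 3 (0.19 log units; within the scatter) for this one change. Compound 1 differs from compound 2 in more than one place, so the earlier numbers could not isolate any single change, whereas this pair does. At this position, and in this one pair, fluoro and chloro cannot be told apart, since the difference is no larger than repeated measurements of the same compound would be expected to show, and nothing measured here offers an explanation for that similarity.

Going by these compounds, only these two halogens have been compared, and only at this one place, so it remains open whether a group of another kind, such as an amine, a methoxy group or a carboxylic acid, would give a similar number there. On these data alone, it is also open whether the same exchange of fluoro and chloro would again make so little difference elsewhere in the molecule or on the core of compound 1.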